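The source may hold more compounds than are shown below. What is called first, only, known or untested is meant among the compounds shown, and "the series" means these compounds.

Compound 3 `O=C(Nc1ccc(Oc2ccc(-c3ncc[nH]3)cc2)cc1)Nc1cc(Br)cc(C(F)(F)F)c1` stands lowest of the three measured compounds in a functional assay on MDA-MB-231 cells (Homo sapiens) for inhibition, read by MTT assay and WST assay, with a stated time of 72 h, tested at 10 uM (a higher number here means more inhibition of growth at the concentration tested, a lower number less inhibition of growth), giving -13.6%. Compound 1 `O=C(Nc1ccc(Oc2ccc(-c3ncc[nH]3)cc2)cc1)Nc1ccc(F)c(C(F)(F)F)c1` gives 26.6% in this assay, and compound 2 `Cc1ccc(NC(=O)Nc2ccc(Oc3ccc(-c4ncc[nH]4)cc3)cc2)cc1` gives 49.3%. The step to compound 4 `O=C(Nc1ccc(Oc2ccc(-c3ncc[nH]3)cc2)cc1)Nc1ccc(F)c(Cl)c1` is 3-chloro-4-fluorophenyl in place of 3-bromo-5-(trifluoromethyl)phenyl on an amide-type nitrogen. For the measured compounds named here, two measured steps bear on it: the change of this same group gave a number 40.2 percentage points lower from compound 1 to compound 3 (beyond the scatter) and a number 62.9 percentage points lower from compound 2 to compound 3 (beyond the scatter), both large. Compound 4 carries a group with the same two substituted positions as compound 1, which gives 26.6%, so compound 4 is expected to rise back toward that value, a step of about a number 38.6 percentage points higher from compound 3 to compound 4 (beyond the scatter). Compound 4 is therefore estimated at 25%, with a range from 5% to 45%.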

Compound 4, percent growth inhibition at one concentration: 4.2%
Beside the measured number, compound 4's estimate is 20.8 percentage points above it, outside the stated range (below it).
By their numbers in this assay, from the lowest: compound 3; then compound 4; then compound 1; then compound 2.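

Replacing a single substituent on the aryl group, with chloro in place of trifluoromethyl on an aromatic carbon, gave a number 22.4 percentage points lower from compound 1 to compound 4 (beyond the scatter) in this assay, so this substituent alone changes the reading. The 3-chloro-4-fluorophenyl group also lies between its neighbours, with a number 17.8 percentage points higher from compound 3 to compound 4 (beyond the scatter) and a number 45.1 percentage points lower from compound 2 to compound 4 (beyond the scatter). Nothing available explains these shifts. On these data alone, what a methoxy group or an amine on this phenyl ring would give remains open. So does whether the order of these four compounds would hold with a different group on the amide-type nitrogen.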